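A few compounds are considered here, and "the series" means these few. Any claim that something is new, unique, unknown or untested is made for them only; others in the source may bear on it.

Working notes on the series. In a functional assay on K562 cells (Homo sapiens) for inhibition, with a stated time of 72 h (on this read-out lower numbers stand for stronger inhibition and higher numbers for weaker inhibition), compound 1 `NC1CCC(Nc2nc(NCc3ccc(-c4ccccc4)cc3)c3ncn(C4CCCC4)c3n2)CC1` gives 530 nM, compound 2 `NC1CCC(Nc2nc(NCc3ccc(-c4ccco4)cc3)c3ncn(C4CCCC4)c3n2)CC1` gives 96 nM and compound 3 `NC1CCC(Nc2nc(NCc3ccc(-n4cccn4)cc3)c3ncn(C4CCCC4)c3n2)CC1` gives 119 nM. Compound 3 stands level with compound 2, with a 1.2-fold higher number from compound 2 to compound 3 (0.09 log units; within the scatter), and clear of the highest number, with a 4.5-fold lower number from compound 1 to compound 3 (0.65 log units; beyond the scatter).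

Compound 4 `NC1CCC(Nc2nc(NCc3ccc(-c4ccco4)nc3)c3ncn(C4CCCC4)c3n2)CC1` differs by 6-(furan-2-yl)pyridin-3-yl in place of 4-(1H-pyrazol-1-yl)phenyl on a saturated chain carbon bound to a nitrogen on an aromatic ring. The furan-2-yl group has a precedent in a 5.5-fold lower number from compound 1 to compound 2 (0.74 log units; beyond the scatter), and the nearest guide is the small 1.2-fold higher number from compound 2 to compound 3 (0.09 log units; within the scatter). Going by the values given here, no measured compound carries the pyridine ring, so that part of the change is untested. No step beyond the scatter is therefore expected in this assay, with a slight lean to a higher number. The expected step is a 1.3-fold higher number from compound 3 to compound 4 (0.10 log units; within the scatter). The estimate for compound 4 is 150 nM, with an expected range of 50 nM to 450 nM.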

Compound 4, half-maximal inhibitory concentration: 67 nM
Beside the measured number, compound 4's estimate is 2.2-fold (0.35 log units) above it; measured number inside the range.
By their numbers in this assay, from the lowest: compounds 4, 2 and 3 (each within the scatter of the next); then compound 1.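

In this assay the pyridine ring is now tested at this position: the 6-(furan-2-yl)pyridin-3-yl group stays level with both earlier five-membered-ring groups, with a 1.4-fold lower number from compound 2 to compound 4 (0.16 log units; within the scatter) and a 1.8-fold lower number from compound 3 to compound 4 (0.25 log units; within the scatter) both within the scatter. The 4-phenylphenyl group alone stands apart, with a 7.9-fold lower number from compound 1 to compound 4 (0.90 log units; beyond the scatter) beyond the scatter. No measured evidence bears on the reason for these numbers.

Open, from the compounds shown here alone, is whether the pyridine ring keeps this level with another group in place of the furan-2-yl, such as an amine or a carboxylic acid.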